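Attachment change on the arylamide end of the series

The source may report more compounds than this note shows. Statements on the series, on what has been measured and on what is new or still open speak of the compounds shown alone.

Compound 1 `COc1ccccc1N1CCN(CCCNC(=O)c2ccc3[nH]ccc3c2)CC1` gives 123 nM in an assay on isolated protein (spleen, strain Sprague-Dawley) for antagonist activity at Alpha-1B adrenergic receptor (Rattus norvegicus), with a stated time of 20 min; a higher number here means weaker binding, a lower number tighter binding. For the measured compounds named here, compound 2 `COc1ccccc1N1CCN(CCCNC(=O)c2cc3ccc(Br)cc3[nH]2)CC1` gives 209 nM in this assay; it stands at the higher of the two numbers measured so far, though a 1.7-fold higher number from compound 1 to compound 2 (0.23 log units; within the scatter) keeps it within the scatter of compound 1. Compound 3 `COc1ccccc1N1CCN(CCCNC(=O)c2cn(C)c3ccccc23)CC1` is not yet measured. Relative to compound 2 the change is 1-methyl-1H-indol-3-yl in place of 6-bromo-1H-indol-2-yl on a carbonyl carbon. Going by the values given here, the only measured step that bears on it is the one from compound 1 to compound 2, which also exchanged the group on the carbonyl carbon for another bicyclic aromatic unit and moved the number by a 1.7-fold higher number from compound 1 to compound 2 (0.23 log units; within the scatter), a shift inside the scatter. On that basis no step beyond the scatter is expected for compound 3, with a slight lean toward the middle of the two measured values. Compound 3 is thus estimated at 160 nM, range 50 nM to 500 nM, meaning an expected step of a 1.3-fold lower number from compound 2 to compound 3 (0.12 log units; within the scatter).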

Compound 3, dissociation constant: 166 nM
Compound 3: the middle estimate sits 1.0-fold (0.02 log units) below what was measured; the measured number falls inside the stated range.
By their numbers in this assay, from the lowest: compounds 1, 3 and 2 (each within the scatter of the next).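

In this assay, a third attachment on the carbonyl carbon again gives no step beyond the scatter: a 1.3-fold lower number from compound 2 to compound 3 (0.10 log units; within the scatter), and a 1.3-fold higher number from compound 1 to compound 3 (0.13 log units; within the scatter). The change from 6-bromo-1H-indol-2-yl to 1-methyl-1H-indol-3-yl removes the bromine and goes from 1 hydrogen-bond donor to 0 hydrogen-bond donors, yet these compounds remain within the scatter of each other, so this assay does not separate the three attachments. Nothing available accounts for this lack of separation.

The compounds shown leave open whether any change at this carbonyl carbon can produce a step beyond the scatter. A carboxylic acid or an amine on the bicyclic group, or a longer chain in its place, would test how far this holds.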